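Replacing Methoxy With Phenyl on Compound 3's Carbonyl

This account rests on a few compounds, and the source may have more. Where it says the series, first, only, none or still open, it means among the compounds named here.

Compound 1 `CCCCCCNC(=O)n1cc(F)c(=O)n(CC2CC2)c1=O`: in an assay on HEK293 cells for inhibition of acid ceramidase (Rattus norvegicus), read by LC-MS, with a stated time of 30 min (a higher number here means a weaker inhibitor, a lower number a stronger inhibitor), compound 1 gives 61 nM.
Compound 2 `CCCCCCNC(=O)n1cc(F)c(=O)n(C(=O)C(C)C)c1=O`: in this assay compound 2 gives 21 nM.
Compound 3 `CCCCCCNC(=O)n1cc(F)c(=O)n(C(=O)OC)c1=O`: in this assay compound 3 gives 7 nM.

Compound 3 has the lowest number of the three and is therefore the strongest inhibitor shown; the steps of an 8.7-fold lower number from compound 1 to compound 3 (0.94 log units; beyond the scatter) and a 3.0-fold lower number from compound 2 to compound 3 (0.48 log units; beyond the scatter) both lie beyond the scatter. Compound 4 `CCCCCCNC(=O)n1cc(F)c(=O)n(C(=O)c2ccccc2)c1=O` differs from compound 3 in one place: phenyl in place of methoxy on a carbonyl carbon. Within the data shown here, only one measured step touches this carbonyl carbon, namely a 3.0-fold lower number from compound 2 to compound 3 (0.48 log units; beyond the scatter), where methoxy in place of isopropyl lowered the number. Compound 4 moves the other way, from methoxy to a carbon group, so a modest rise in this assay is expected, of about the size seen in that step: a 2.9-fold higher number from compound 3 to compound 4 (0.46 log units; beyond the scatter). For compound 4 the expected value in this assay is 20 nM, with a range from 8 nM to 50 nM.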

Compound 4, half-maximal inhibitory concentration: 20 nM
Estimate against measurement, compound 4: no gap at the digits printed; the range from low to high includes it.
By their numbers in this assay, from the lowest: compound 3; then compounds 4 and 2 (each within the scatter of the next); then compound 1.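

On the carbonyl carbon, the two carbon groups now read alike in this assay: the ring-bearing phenyl and the branched isopropyl cannot be told apart (a 1.1-fold lower number from compound 2 to compound 4 (0.02 log units; within the scatter)), while methoxy stands clear of phenyl (a 2.9-fold higher number from compound 3 to compound 4 (0.46 log units; beyond the scatter)), just as it does of isopropyl. Benzoyl also joins the other two carbonyl groups on this aromatic nitrogen in giving a lower number than cyclopropylmethyl (a 3.1-fold lower number from compound 1 to compound 4 (0.48 log units; beyond the scatter)), so the full set of three acyl-type groups shown falls on the same side of that comparison. No measurement shown here accounts for these differences.

As far as these compounds go, it remains open whether a longer alkoxy chain on this carbonyl carbon would read like methoxy. From the compounds shown here alone, it is equally open where an amine at the same place would fall, with methoxy or with phenyl and isopropyl.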